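Methyl on the core: from compound 3 to compound 4

The compounds below may be only part of what the source reports. "The series", "measured", "known", "first", "only" and "open" are said of these compounds alone.

Compound 1 `Cc1cnc(Nc2ccc(S(C)(=O)=O)cc2)nc1Nc1nc2ccc(Cl)cc2s1` – 13400 nM
Compound 2 `Cc1cnc(Nc2ccc(S(C)(=O)=O)cc2)nc1Nc1nc2ccccc2s1` – > 50000 nM
Compound 3 `CS(=O)(=O)c1ccc(Nc2nccc(Nc3nc4ccc(F)cc4s3)n2)cc1` – 1940 nM

In a functional assay on PC-3 cells (Homo sapiens) for antiproliferative activity, read by MTT assay, with a stated time of 48 h (on this read-out higher numbers stand for weaker inhibition and lower numbers for stronger inhibition), compound 3 gives 1940 nM, the lowest of the two numbers shown, with compound 1 at 13400 nM as the nearest. For compound 2 the result is only a limit, (the limit of > 50000 nM in this assay, at which 1 of the 3 values shown sits). Compound 4 `Cc1cnc(Nc2ccc(S(C)(=O)=O)cc2)nc1Nc1nc2ccc(F)cc2s1` differs from compound 3 by methyl in place of hydrogen on an aromatic carbon. Among the compounds with values here, the only measured step, an at least 3.7-fold higher number from compound 1 to compound 2 (0.57 log units; beyond the scatter), concerns a different position and does not bear on a methyl. Compound 1 and compound 3 differ in two places, so their values alone give no clean reading of the methyl; they suggest, weakly, a higher number. Compound 4 is therefore expected to give 6000 nM, with a range from 2000 nM to 20000 nM, an expected step of a 3.1-fold higher number from compound 3 to compound 4 (0.49 log units; beyond the scatter).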

Compound 4, half-maximal inhibitory concentration: > 50000 nM
Compound 4 was reported as a limit (the forecaster's own chance of this, stated with the estimate: 10%); at least 8.3-fold (0.92 log units) between middle value and limit.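

In this assay this position now has its first clean reading, with an at least 25-fold higher number from compound 3 to compound 4 (1.41 log units; beyond the scatter) for methyl in place of hydrogen, a large step whose full size stays hidden behind the limit of compound 4. With the methyl present, fluoro in place of chloro gives an at least 3.7-fold higher number from compound 1 to compound 4 (0.57 log units; beyond the scatter) and so runs the same way as the earlier loss of chloro. Compound 2 and compound 4 both stand at a limit, so the step between them cannot be read: the limit of > 50000 nM in this assay, at which 2 of the 4 values shown sit.

As far as these compounds go, whether an ethyl or a methoxy on this carbon would read like the methyl stays open. So does whether an amine there would stay close to compound 3.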